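Lengthening the Selenium Chain on an Aminoquinazoline

The compounds below may be only part of what the source reports. "The series", "measured", "known", "first", "only" and "open" are said of these compounds alone.

Compound 1 `C[Se]c1nc(N)c2ccccc2n1` was tested in a functional assay on HT-29 cells (Homo sapiens) for cytotoxicity, read by MTT assay, with a stated time of 72 h (on this read-out higher numbers stand for weaker inhibition of growth and lower numbers for stronger inhibition of growth), where compound 1 gives 27600 nM. Among the three measured compounds this is the second highest number. Its nearest neighbour is compound 2 `CSc1ccc(CNc2nc(SC)nc3ccccc23)cc1`, which in this assay gives 34700 nM, a gap that lies within the scatter of the method. Compound 3 `C[Se]c1nc([Se]C)c2ccccc2n1` stands furthest away, and in this assay compound 3 gives 7460 nM.

Compound 4 `CCCCC[Se]c1nc(N)c2ccccc2n1` differs from compound 1 by butyl in place of hydrogen on a saturated chain carbon bound to a selenium atom. Among the compounds with values here, the only measured step that touches this core is a 3.7-fold lower number from compound 1 to compound 3 (0.57 log units; beyond the scatter), but that step swaps one group for an entirely different one, whereas the move to compound 4 merely lengthens a chain that is already present. Within the data shown here, no measured pair shows what a longer chain on selenium does here, so the step of a 3.7-fold lower number from compound 1 to compound 3 (0.57 log units; beyond the scatter) is only a loose guide to how far this series can move.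

With nothing directly comparable, a change of modest size, if any, is expected for compound 4 in this assay, as a 1.5-fold lower number from compound 1 to compound 4 (0.19 log units; within the scatter). For compound 4 the estimated value is 18000 nM, with a range from 6000 nM to 45000 nM.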

Compound 4, concentration for 50% growth inhibition: 40300 nM
Compound 4: the middle estimate sits 2.2-fold (0.35 log units) below what was measured; the measured number falls inside the stated range.
By their numbers in this assay, from the lowest: compound 3; then compounds 1, 2 and 4 (each within the scatter of the next).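

In this assay the change from methyl to pentyl on the selenium atom gives a 1.5-fold higher number from compound 1 to compound 4 (0.16 log units; within the scatter), so compound 1 and compound 4 cannot be told apart on this read-out. Within the data shown here, earlier compounds showed a step only where a whole group on the aromatic core was exchanged, whereas this pair is the first to test the chain on selenium, and here butyl in place of hydrogen on a saturated chain carbon bound to a selenium atom leaves the number within the usual spread of repeated measurements. No measurement shown here offers an explanation for this result.

The compounds shown leave open whether a group of another shape on selenium, such as a benzyl group or a chain ending in an amine or a carboxylic acid, would also leave the number within the scatter. They also leave open whether a longer chain on selenium would behave in the same way on the core of compound 3 , which gives 7460 nM in this assay and carries a second selenium group in place of the amine.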